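Adding 4-methylpiperazin-1-yl to compound 1

This account rests on a few compounds, and the source may have more. Where it says the series, first, only, none or still open, it means among the compounds named here.

compound 1 (`O=C(/C=C/c1cccc(/C=C/C(=O)c2ccccc2)c1)NO`): 12000 nM
compound 2 (`CN1CCN(c2ccccc2C(=O)/C=C/c2cccc(/C=C/C(=O)NO)c2)CC1`): 177000 nM

Among the compounds with values here, in a physicochemical assay for solubility, at pH 7.4 (a lower number here means a less soluble compound, a higher number a more soluble compound), compound 1 gives 12000 nM and so stands lowest of the two numbers known so far. Compound 3 (`CN1CCN(c2cccc(C(=O)/C=C/c3cccc(/C=C/C(=O)NO)c3)c2)CC1`) differs from it by a single change (4-methylpiperazin-1-yl in place of hydrogen on an aromatic carbon): 4-methylpiperazin-1-yl in place of hydrogen on an aromatic carbon, meta to a large group. Within the data shown here, one measured step bears on this, with the same group at another place: a 15-fold higher number from compound 1 to compound 2 (1.17 log units; beyond the scatter) and thus a large one. The place differs, and a single step is thin evidence. A rise in this assay is still expected, similar in size or somewhat smaller. For compound 3 the estimated value is 100000 nM with an expected range from 35000 nM to 250000 nM as its ends. This would be an expected 8.3-fold higher number from compound 1 to compound 3 (0.92 log units; beyond the scatter) in all.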

Compound 3, solubility: 46000 nM
For compound 3 the middle estimate is 2.2-fold (0.34 log units) above the measured one; measured number inside the range.
By their numbers in this assay, from the lowest: compound 1; then compound 3; then compound 2.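

In this assay, 4-methylpiperazin-1-yl on an aromatic carbon, meta to a large group, gives a 3.8-fold higher number from compound 1 to compound 3 (0.58 log units; beyond the scatter). The rise is therefore not tied to the one place seen earlier, although it is smaller here than the other step with the same group, a 15-fold higher number from compound 1 to compound 2 (1.17 log units; beyond the scatter). The place of the group thus matters to the size of the rise, but nothing available here explains that difference.

These two places for one group leave open whether a smaller amine, such as dimethylamino, or a carboxylic acid at this same position would move the number in the same direction. They also leave open whether a longer chain ending in the same 4-methylpiperazin-1-yl group would keep the rise.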